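A few compounds are considered here, and "the series" means these few. Any claim that something is new, unique, unknown or untested is made for them only; others in the source may bear on it.

Working notes on the series. In a functional assay on NCI-H661 cells (Homo sapiens) for antiproliferative activity, read by MTT assay, with a stated time of 72 h (a lower number here means a stronger inhibitor, a higher number a weaker inhibitor), compound 1 (`O=C(CCCCCCc1nc(-c2cccc([N+](=O)[O-])c2)no1)NO`) gives 16100 nM as its measured value. Compound 2 (`O=C(CCCCCCc1nc(-c2cccs2)no1)NO`) gives 9460 nM in the same test. Within the data shown here, these two numbers lie within the usual scatter of each other, so compound 1 stands level with the only other measured compound and no ranking can be drawn between them.

Compound 3 (`O=C(CCCCCCc1nc(-c2cccc([N+](=O)[O-])c2)no1)C(F)(F)F`) keeps the core of compound 1 and changes one place: trifluoromethyl in place of hydroxyamino on a carbonyl carbon. This turns the hydroxycarbamoyl into (trifluoromethyl)carbonyl. Among the measured compounds shown here, no measured pair shows this change, so the size of the step is a judgement and not a reading from the data. The expected step is a 2.2-fold higher number from compound 1 to compound 3 (0.34 log units; beyond the scatter) in this assay and is taken as a modest move toward a weaker inhibitor, only slightly beyond the scatter, with real uncertainty in both directions. For compound 3 the estimated value is 35000 nM with an expected range from 12000 nM to 100000 nM.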

Compound 3, half-maximal inhibitory concentration: 6430 nM
For compound 3 the middle estimate is 5.4-fold (0.74 log units) above the measured one; the measured number lies below the stated range.
By their numbers in this assay, from the lowest: compounds 3, 2 and 1 (each within the scatter of the next, the first and the last beyond it).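

In this assay, among these compounds, the first change at this place runs toward a stronger inhibitor: trifluoromethyl in place of hydroxyamino on a carbonyl carbon gives a 2.5-fold lower number from compound 1 to compound 3 (0.40 log units; beyond the scatter) and thus a modest gain, not a loss. The entering group counts no hydrogen-bond donors or acceptors, so in this one pair, with the rest of compound 1 unchanged, the hydrogen-bond donors and the acceptor of hydroxyamino are not required to keep the antiproliferative number at this level. Nothing on hand accounts for the direction or the size of this step.

Open, as far as these compounds go, is whether other groups on the same carbonyl carbon, such as a hydroxyl giving a carboxylic acid, a methyl giving a methyl ketone or a plain amine giving a primary amide, would hold this level or lose it. Also open, from the compounds shown here alone, is whether the same replacement would give a step of similar direction and size on the core of compound 2, since the present reading rests on a single pair.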